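A Chlorine Added to the Terminal Phenyl Ring

The source may hold more compounds than are shown below. What is called first, only, known or untested is meant among the compounds shown, and "the series" means these compounds.

Of the compounds shown here, three sharing one core have been measured in a functional assay on MKN-45 cells (Homo sapiens) for cytotoxicity, read by MTT assay, with a stated time of 72 h; a lower number here means a stronger inhibitor, a higher number a weaker inhibitor. Compound 1 `CN(C)CCNc1nc(-c2ccc(NC(=O)Nc3ccccc3)cc2)nc2ccsc12` gives 1120 nM. Compound 2 `CCN(CC)CCCNc1nc(-c2ccc(NC(=O)Nc3ccccc3)cc2)nc2ccsc12` gives 980 nM, the lowest of the three numbers, though all three lie within the usual scatter of one another. Compound 3 `CCN(CC)CCCNc1nc(-c2ccc(NC(=O)Nc3ccccc3Cl)cc2)nc2c(Cl)c(Cl)sc12` differs from compound 2 in several places at once. Compound 3 gives 1450 nM. Among the measured compounds shown here, the one single-point step among them, a 1.1-fold lower number from compound 1 to compound 2 (0.06 log units; within the scatter), concerns the amine chain and not the urea end of the molecule.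

Compound 4 `CCN(CC)CCCNc1nc(-c2ccc(NC(=O)Nc3ccc(Cl)cc3)cc2)nc2ccsc12` arises from compound 2 by chloro in place of hydrogen on an aromatic carbon. For the measured compounds named here, no measured step touches this position on its own; the step from compound 1 to compound 2 is the only clean comparison, and it stayed within the scatter. Going by the values given here, compound 3, the only other compound carrying chlorine, was changed in more than one place, so its number cannot be tied to any single substitution. The expectation is therefore a step of a 1.0-fold higher number from compound 2 to compound 4 (0.01 log units; within the scatter) for compound 4, nothing beyond the scatter. Compound 4 is estimated at 1000 nM, with a range of 450 nM to 2300 nM.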

Compound 4, half-maximal inhibitory concentration: 180 nM
Beside the measured number, compound 4's estimate is 5.6-fold (0.74 log units) above it; the measured number lies below the stated range.
By their numbers in this assay, from the lowest: compound 4; then compounds 2, 1 and 3 (each within the scatter of the next).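

A single chlorine on the terminal ring gives a 5.4-fold lower number from compound 2 to compound 4 (0.74 log units; beyond the scatter), a step beyond the usual scatter in this assay. Among the compounds shown here, the only earlier single-point step, a 1.1-fold lower number from compound 1 to compound 2 (0.06 log units; within the scatter), lay within the scatter and concerned the amine chain, so this is the first clean sign that a change at the urea end, here phenyl to 4-chlorophenyl, can move the number. Nothing measured here explains why the number falls.

Going by these compounds, whether the step belongs to chlorine itself or would also come with another group at this place, such as fluoro, methyl or methoxy, remains open. Compound 3 also carries a chlorine on this ring, but it differs from compound 4 in more than one place, so it cannot show whether the chlorine's place on the ring matters.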